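Halogen swap on the benzoyl ring of two series

The compounds below may be only part of what the source reports. "The series", "measured", "known", "first", "only" and "open" are said of these compounds alone.

Measured so far:
compound 1 `Cc1ccc(S(=O)(=O)/C(=C/c2ccc(C)s2)C(=O)c2ccc(Br)cc2)cc1` — a functional assay on DU-145 cells (Homo sapiens) for inhibition, read by trypan blue exclusion, with a stated time of 96 h; a lower number here means a stronger inhibitor of growth, a higher number a weaker inhibitor of growth: 25000 nM
compound 2 `Cc1ccc(S(=O)(=O)/C(=C/c2ccc(C)s2)C(=O)c2ccc(Cl)cc2)cc1` — this assay: 50000 nM
compound 3 `O=C(/C(=C\c1ccc(O)c([N+](=O)[O-])c1)Sc1ccccc1Br)c1ccc(Br)cc1` — this assay: 10000 nM

Compound 1 and compound 2 share a core and differ in one place only: chloro in place of bromo on an aromatic carbon. The step it made, a 2.0-fold higher number from compound 1 to compound 2 (0.30 log units; within the scatter), is within the scatter, so the two values show no real order between them.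

Compound 3 has a different core; the difference between the two cores is not broken down here. Its value is the lowest of the three, and its gap to compound 1 and to compound 2 is beyond the scatter in both cases.

Compound 4 `O=C(/C(=C\c1ccc(O)c([N+](=O)[O-])c1)Sc1ccccc1Br)c1ccc(Cl)cc1` is not yet measured. It stands to compound 3 as compound 2 stands to compound 1: chloro in place of bromo on an aromatic carbon. The place lines of the two changes read the same, so this is the same change made on another core. Within the data shown here, the only guide to its effect is the step from compound 1 to compound 2, which is small and within the scatter. On that basis the step from compound 3 to compound 4 in this assay is expected to be of similar size, a 1.8-fold higher number from compound 3 to compound 4 (0.26 log units; within the scatter), because the measured step of a 2.0-fold higher number from compound 1 to compound 2 (0.30 log units; within the scatter) was small. Compound 4 is therefore estimated at 18000 nM in this assay, with a range of 8000 nM to 40000 nM. This rests on a single measured pair and carries the uncertainty of that.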

Compound 4, concentration for 50% growth inhibition: 25000 nM
Estimate against measurement, compound 4: 1.4-fold (0.14 log units) below, within the range that was stated.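

In this assay, the change from 4-bromophenyl to 4-chlorophenyl gives a 2.5-fold higher number from compound 3 to compound 4 (0.40 log units; beyond the scatter), and setting this beside the step on the other core shows that the two steps agree: the same change on two cores in this assay, a 2.0-fold higher number (0.30 log units; within the scatter) from compound 1 to compound 2 and a 2.5-fold higher number (0.40 log units; beyond the scatter) from compound 3 to compound 4, 1.3-fold (0.10 log units) apart, within the scatter of two such steps

Among these compounds, the change therefore carries over between these two cores with a step of like size, and the two steps cannot be told apart, even though only the step on the core of compound 3 lies beyond the scatter. This is a single pair of steps on two cores in one cell assay, so it does not show that the change would behave alike on a further core or in another read-out, and it gives no explanation of the step itself.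

Going by these compounds, only bromo and chloro appear at this place, so what fluoro, methoxy or a nitrile would do there remains open. On these data alone, the two cores differ in more than one place, so the part each difference plays cannot be read, and how an amine or a carboxylic acid in place of the hydroxy group on the core of compound 3 would read also remains open.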